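The compounds below may be only part of what the source reports. "The series", "measured", "known", "first", "only" and "open" are said of these compounds alone.

Measured compounds:
compound 1, `Nc1ccc(/C=C2\SC(=O)N(Cc3ccc(Cl)cc3)C2=O)cc1`, 60000 nM
compound 2, `C=C(Br)C(=O)Nc1cccc(/C=C2\SC(=O)N(Cc3cccc(Cl)c3)C2=O)c1`, 1700 nM
compound 3, `Nc1cccc(/C=C2\SC(=O)N(Cc3ccc(C(F)(F)F)cc3)C2=O)c1`, > 250000 nM

In a functional assay on FM3A cells (Mus musculus) for cytotoxicity, read by cell counting, with a stated time of 2 days (on this read-out lower numbers stand for stronger inhibition and higher numbers for weaker inhibition), compound 1 gives 60000 nM, the highest of the two numbers reported; compound 2 gives 1700 nM, a lower number beyond the scatter. For compound 3 the assay reports only a limit, (the limit of > 250000 nM in this assay, at which 1 of the 3 values shown sits), and not a number. Compound 4, `Cc1ccc(CN2C(=O)S/C(=C\c3ccc(N)cc3)C2=O)cc1`, differs from compound 1 in one place: methyl in place of chloro on an aromatic carbon. Within the data shown here, no step between measured compounds shows what this change does, so compound 4 is expected to stay close to compound 1, within the scatter and without a clear direction, a step of a 1.3-fold higher number from compound 1 to compound 4 (0.12 log units; within the scatter). Compound 4 is therefore estimated at 80000 nM, between 25000 nM and 250000 nM.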

Compound 4, half-maximal inhibitory concentration: > 250000 nM
Compound 4: only a limit was reported (the forecaster's own chance of this, stated with the estimate: 15%); middle value at least 3.1-fold (0.49 log units) from the limit.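

In this assay, methyl in place of chloro on an aromatic carbon gives an at least 4.1-fold higher number from compound 1 to compound 4 (0.61 log units; beyond the scatter). This is the first step shown at this position, and it shows that the position does not tolerate this change without loss: inhibition weakens beyond the scatter. The result for compound 4 is a limit and not a number, so the full size of the step cannot be read: the limit of > 250000 nM in this assay, at which 2 of the 4 values shown sit.

On these data alone, whether fluoro, methoxy or an amine at this place would hold the number of compound 1 stays open. As far as these compounds go, whether the same change acts alike on a different core also stays open.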